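This account rests on a few compounds, and the source may have more. Where it says the series, first, only, none or still open, it means among the compounds named here.

Measured in a functional assay on NCI-H460 cells (Homo sapiens) for antiproliferative activity, read by MTT assay, with a stated time of 48 h; on this read-out higher numbers stand for weaker inhibition and lower numbers for stronger inhibition:
compound 1 `COc1ccc(-c2nc3cccc(-c4cc(OC)c(OC)c(OC)c4)c3o2)cc1`: 3500 nM
compound 2 `COc1cccc(-c2nc3cccc(-c4cc(OC)c(OC)c(OC)c4)c3o2)c1`: > 25000 nM, a limit
compound 3 `COc1cc(-c2cccc3nc(-c4ccc(Br)cc4)oc23)cc(OC)c1OC`: > 25000 nM, a limit

Compound 3 gives no number, only (the limit of > 25000 nM in this assay, at which 2 of the 3 values shown sit). Compound 4 `COc1cc(-c2cccc3nc(-c4cccc(O)c4)oc23)cc(OC)c1OC` carries 3-hydroxyphenyl in place of 4-bromophenyl on an aromatic carbon. Two measured changes at this same place bear on it: an at least 7.1-fold higher number from compound 1 to compound 2 (0.85 log units; beyond the scatter) and an at least 7.1-fold higher number from compound 1 to compound 3 (0.85 log units; beyond the scatter). The closest measured group is the 3-methoxyphenyl of compound 2, and an at least 7.1-fold higher number from compound 1 to compound 2 (0.85 log units; beyond the scatter) gives no support for a strong gain. Only a modest lower number, or no readable change, is therefore expected in this assay. The estimated move is an at least 1.6-fold lower number from compound 3 to compound 4 (0.22 log units; that floor lies within the scatter). For compound 4 the estimate is 15000 nM, with an expected range of 4000 nM to 25000 nM.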

Compound 4, half-maximal inhibitory concentration: 1900 nM
Beside the measured number, compound 4's estimate is 7.9-fold (0.90 log units) above it; measured number outside the range, below it.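

In this assay, the 3-substituted phenyl at this place is not inactive in itself: hydrogen in place of methyl on the oxygen gives an at least 13-fold lower number from compound 2 to compound 4 (1.11 log units; beyond the scatter), so that methyl alone decides the outcome within this pair. Replacing 4-bromophenyl with 3-hydroxyphenyl gives an at least 13-fold lower number from compound 3 to compound 4 (1.11 log units; beyond the scatter). Compared with 4-methoxyphenyl, 3-hydroxyphenyl gives a 1.8-fold lower number from compound 1 to compound 4 (0.27 log units; within the scatter), so these two groups are not separated here.

As far as these compounds go, whether a free hydroxyl is specifically required remains open, since 3-aminophenyl would test another group at this place. The 4-hydroxyphenyl group would show whether the hydroxyl also works at the other ring position.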